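The compounds below may be only part of what the source reports. "The series", "measured", "known", "first", "only" and "open" are said of these compounds alone.

In a functional assay on A549 cells (Homo sapiens) for cytotoxicity, read by MTT assay, with a stated time of 6 days (a higher number here means a weaker inhibitor, a lower number a stronger inhibitor), compound 1 `CC(C)=CCC/C(=C/CC/C(C)=C/CC/C(C)=C/CC1=CC(=O)C(C)=CC1=O)CO` gives > 48800 nM, which is a limit of the assay rather than a number. Compound 2 `CC(C)=CCC/C(C)=C/CC/C(C)=C/CC[C@](C)(O)/C=C\c1cc(O)c(C)cc1O` gives > 48500 nM in this assay, again only a limit. Where compound 2 stands is therefore known only as that limit, (the limit of > 48500 nM in this assay, at which 1 of the 2 values shown sits), with no number beneath it. Compound 3 `CC(C)=CCC/C(C)=C/[C@@H](O)C/C(C)=C/CC[C@](C)(O)/C=C\c1cc(O)c(C)cc1O` carries hydroxy in place of hydrogen on a saturated chain carbon bound to a double-bonded chain carbon and a saturated chain carbon. For the measured compounds named here, no measured step with a single change is available here, so the expected step from compound 2 to compound 3 is a step that the limit leaves unreadable from compound 2 to compound 3, estimated as none beyond the scatter. Compound 3 is expected to give 50000 nM, within a range from 20000 nM to 150000 nM, and most probably again only as a limit.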

Compound 3, half-maximal inhibitory concentration: 42300 nM
Beside the measured number, compound 3's estimate is 1.2-fold (0.07 log units) above it; the range from low to high includes it.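

Placing hydroxy on a saturated chain carbon bound to a double-bonded chain carbon and a saturated chain carbon gives an at least 1.1-fold lower number from compound 2 to compound 3 (0.05 log units; that floor lies within the scatter) in this assay. For the compounds shown here, this change yields the only actual number among the three compounds, yet it shows no gain beyond the scatter and no strong cytotoxicity. The true size of the step stays unknown because compound 2 gives only a limit: the limit of > 48500 nM in this assay, at which 1 of the 3 values shown sits.

The compounds shown leave open whether a different group at this place, such as a methoxy or an amine, would give a clearly lower number. As far as these compounds go, the effect of the opposite spatial arrangement of the hydroxy also remains open.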